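Thiazolyl for pyrrolidinylsulfonyl in the aryl amide series

A few compounds are considered here, and "the series" means these few. Any claim that something is new, unique, unknown or untested is made for them only; others in the source may bear on it.

The series is read in a functional assay on PC-3 cells (Homo sapiens), with a stated time of 24 h, tested at 10 uM; a higher number here means more inhibition at the concentration tested (going by the name of the read-out), a lower number less inhibition. Compound 1 `O=C(Nc1cccc(Oc2ccccc2)c1)C1CCCN(C(=O)c2cc(C(F)(F)F)cc(C(F)(F)F)c2)C1` carries a phenoxy group on the aryl amide; in this assay compound 1 gives < 30%, which is a limit of the assay and not a number. Compound 2 `O=C(Nc1cccc(S(=O)(=O)N2CCCC2)c1)C1CCCN(C(=O)c2cc(C(F)(F)F)cc(C(F)(F)F)c2)C1` carries (pyrrolidin-1-yl)sulfonyl in place of that group; in this assay compound 2 gives < 30%, again a limit rather than a number. Compound 3 `O=C(CCNC(=O)c1cc(C(F)(F)F)cc(C(F)(F)F)c1)Nc1ccc(Cl)cc1`, with an open-chain linker instead of the shared ring, gives < 10% in this assay, also a limit. Within the data shown here, the single step measured in one place, a step that the two limits leave unreadable from compound 1 to compound 2, is consequently unreadable in size and direction.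

Compound 2 thus stands at the limit of < 30% in this assay, at which 2 of the 3 values shown sit, while the remaining value sits at the limit of < 10% in this assay, at which 1 of the 3 values shown sits; no number exists for compound 2 in this assay.

Compound 4 `Cc1nc(-c2cccc(NC(=O)C3CCCN(C(=O)c4cc(C(F)(F)F)cc(C(F)(F)F)c4)C3)c2)cs1` differs from compound 2 in one place: 2-methyl-1,3-thiazol-4-yl in place of (pyrrolidin-1-yl)sulfonyl on an aromatic carbon. Among the measured compounds shown here, no measured step bears on this change with a readable size, so no shift beyond the scatter can be expected for a step that the limit leaves unreadable from compound 2 to compound 4. Compound 4 is therefore estimated to give 12% in this assay, within a range from 0% to 35%, and most probably the result is expected to appear again only as a limit.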

Compound 4, a percentage reported as inhibition, at one concentration (the size of the read-out at that concentration, not a potency): 42%
Beside the measured number, compound 4's estimate is 30 percentage points below it; measured number outside the range, above it.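

In this assay, 2-methyl-1,3-thiazol-4-yl in place of (pyrrolidin-1-yl)sulfonyl on the aromatic carbon gives a number at least 12 percentage points higher from compound 2 to compound 4 (beyond the scatter), and in place of phenoxy it gives a number at least 12 percentage points higher from compound 1 to compound 4 (beyond the scatter). Both sizes are floors, as each step starts from a limit of the assay and not from a number, yet they show that the group at this place can move the read-out beyond the scatter. The earlier compounds could not show this: the step between compound 1 and compound 2 cannot be read, and both compounds stand at a shared value that is a limit and not a number: the limit of < 30% in this assay, at which 2 of the 4 values shown sit.

As far as these compounds go, it remains open whether the gain rests on the thiazole ring or on its methyl group, and how a plain thiazol-4-yl, a phenyl ring, an amine or a carboxylic acid would read at this place. Also open is how far the gain depends on the shared core, as compound 3 differs from compound 4 in more than one place and allows no comparison, and nothing shown gives a measured property of either group that could account for the step.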